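A few compounds are considered here, and "the series" means these few. Any claim that something is new, unique, unknown or untested is made for them only; others in the source may bear on it.

Measured in an ADME assay on HEK293 cells (Homo sapiens) for cytotoxicity, read by MTT assay, with a stated time of 48 h; on this read-out lower numbers stand for stronger inhibition and higher numbers for weaker inhibition:
Compound 1 `CN(C)CCn1c(N)c(-c2nc3ccccc3[nH]2)c2nc(C#N)c(C#N)nc21`: 9730 nM
Compound 2 `CN(C)CCn1c(N)c(-c2nc3cc(Cl)ccc3[nH]2)c2nc(C#N)c(C#N)nc21`: > 50000 nM

From the compounds shown here alone, the entry for compound 2 is a limit of this assay and not a number, so its true position remains open. Compound 3 `CN(C)CCCCn1c(N)c(-c2nc3cc(Cl)ccc3[nH]2)c2nc(C#N)c(C#N)nc21` keeps the chloro of compound 2 but carries 2-(dimethylamino)ethyl in place of dimethylamino on a saturated chain carbon, two bonds along the chain from an aromatic nitrogen. Among the measured compounds shown here, only one measured step exists, an at least 5.1-fold higher number from compound 1 to compound 2 (0.71 log units; beyond the scatter), and it lies beyond the scatter. That step is chloro in place of hydrogen on an aromatic carbon and leaves the chain untouched, so it gives no size for this change. No step beyond the scatter is therefore expected in either direction in this assay. The expected step is an at least 1.2-fold lower number from compound 2 to compound 3 (0.09 log units; that floor lies within the scatter). Compound 3 is estimated at 40000 nM, with an expected range from 12000 nM to 80000 nM.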

Compound 3, half-maximal inhibitory concentration: 4730 nM
Estimate against measurement, compound 3: 8.5-fold (0.93 log units) above, and the stated range ends above it.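

In this assay, among the compounds shown here, the earlier step changed only the chloro and left the chain untouched, so this is the first view of what the chain itself does. With the chloro held in place, 2-(dimethylamino)ethyl in place of dimethylamino on a saturated chain carbon, two bonds along the chain from an aromatic nitrogen, gives an at least 10-fold lower number from compound 2 to compound 3 (1.02 log units; beyond the scatter), which shows that this position is far from silent in this assay. The entry for compound 2 is a limit of the assay and not a number, so the step gives only a floor for the size of the change: the limit of > 50000 nM in this assay, at which 1 of the 3 values shown sits.

The compounds shown leave open whether the chain change would give a step of like size on the core without the chloro, as in compound 1. They also leave open how a 3-(dimethylamino)propyl chain, or a chain ending in a morpholine ring, would read here.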